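Chain shortening from compound 1 to compound 4

The compounds below may be only part of what the source reports. "The series", "measured", "known", "first", "only" and "open" are said of these compounds alone.

In a functional assay on DU-145 cells (Homo sapiens) for inhibition, read by MTT assay, with stated times of 18 h and 4 h (on this read-out higher numbers stand for weaker inhibition and lower numbers for stronger inhibition), compound 1 `CCCCCCCCCCOP(=O)(O)OCCSC(=S)N1CCCCCC1` gives 24000 nM, and compound 3 `CCCCCCCCCCOP(=O)(O)OCCSC(=S)N1CCCCC1` gives 29300 nM. These two form the low end of the three numbers and cannot be separated: a 1.2-fold higher number from compound 1 to compound 3 (0.09 log units; within the scatter). Compound 2 `CCCCCCCCCCOP(=O)(O)OCCSC(=S)N1CCN(C)CC1` stands apart at 82300 nM, with a 3.4-fold higher number from compound 1 to compound 2 (0.54 log units; beyond the scatter) and a 2.8-fold lower number from compound 2 to compound 3 (0.45 log units; beyond the scatter).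

Compound 4 `CCCCCCOP(=O)(O)OCCSC(=S)N1CCCCCC1` keeps the azepan-1-yl group of compound 1 and alters the chain. The change is hydrogen in place of butyl on a saturated chain carbon, six bonds along the chain from an oxygen on an unsaturated carbon.

All three measured steps change only the group on the thiocarbonyl carbon, so none of them tests the chain. They give only a sense of scale, the largest being a 3.4-fold higher number from compound 1 to compound 2 (0.54 log units; beyond the scatter). A step of modest size or somewhat more, toward a higher number in this assay, is a tentative expectation, and the direction is unsupported by any measurement. The expected step is a 2.3-fold higher number from compound 1 to compound 4 (0.36 log units; beyond the scatter). For compound 4 the estimate is 55000 nM, with an expected range of 25000 nM to 130000 nM.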

Compound 4, half-maximal inhibitory concentration: 77400 nM
Compound 4: middle estimate off by 1.4-fold (0.15 log units), on the low side; low and high end bracket the measured number.
By their numbers in this assay, from the lowest: compounds 1 and 3 (each within the scatter of the next); then compounds 4 and 2 (each within the scatter of the next).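

In this assay, among the compounds shown here, the step of a 3.2-fold higher number from compound 1 to compound 4 (0.51 log units; beyond the scatter) is the first reading on the chain itself, as every earlier step changed only the group on the thiocarbonyl carbon. With the azepan-1-yl group held, hydrogen in place of butyl at this saturated chain carbon is a modest step beyond the scatter, in the same size class as the largest change of that group, a 3.4-fold higher number from compound 1 to compound 2 (0.54 log units; beyond the scatter), so this position is at least as able to move the number as the group on the thiocarbonyl carbon. Nothing available here accounts for the change.

On these data alone, whether an octyl chain falls between compound 1 and compound 4, or a longer chain such as dodecyl lowers the number further, remains open. Also open, as far as these compounds go, is whether the same shortening gives a similar step with a piperidin-1-yl or 4-methylpiperazin-1-yl group in place of azepan-1-yl.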